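Swapping the carbonyl substituent in a low-potency series

The source may hold more compounds than are shown below. What is called first, only, known or untested is meant among the compounds shown, and "the series" means these compounds.

Four compounds share one core and differ in the group on a carbonyl carbon: compound 1 (`O=C(Nc1ccc(Cl)c(-c2nnc3c(Cl)cccn23)c1)c1ccc(C(F)(F)F)cc1Cl`), compound 2 (`O=C(Nc1ccc(Cl)c(-c2nnc3c(Cl)cccn23)c1)c1ccccn1`), compound 3 (`O=C(Nc1ccc(Cl)c(-c2nnc3c(Cl)cccn23)c1)c1cccc(Cl)c1`) and compound 4 (`Cc1cc(Cl)ccc1C(=O)Nc1ccc(Cl)c(-c2nnc3c(Cl)cccn23)c1`). In a functional assay on MDA-MB-231 cells (Homo sapiens) for antiproliferative activity, read by MTT assay, with stated times of 72 h and 4 h (a lower number here means a stronger inhibitor, a higher number a weaker inhibitor), compound 2 gives 92000 nM. Compound 3 gives 66100 nM, and these two numbers lie within the scatter of each other. Compound 1 gives > 100000 nM, which is a limit and not a number.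

The step now in view is 4-chloro-2-methylphenyl in place of pyridin-2-yl on a carbonyl carbon. Going by the values given here, one measured step bears on it: a 1.4-fold lower number from compound 2 to compound 3 (0.14 log units; within the scatter), with 3-chlorophenyl in place of pyridin-2-yl at the same place. Because a 1.4-fold lower number from compound 2 to compound 3 (0.14 log units; within the scatter) no step beyond the scatter is expected in this assay. The expected change is a 1.2-fold lower number from compound 2 to compound 4 (0.09 log units; within the scatter). A reading for compound 4 could also end at the limit of > 100000 nM in this assay, at which 1 of the 3 values shown sits.

Compound 4 is estimated at 75000 nM, with an expected range of 25000 nM to 100000 nM.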

Compound 4, half-maximal inhibitory concentration: > 100000 nM
Compound 4 gave a limit, no number; the forecaster's own chance of this, stated with the estimate: 30%; middle value at least 1.3-fold (0.12 log units) from the limit.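

In this assay compound 4 gives only a limit, so with 4-chloro-2-methylphenyl on the carbonyl carbon the steps are floors and not sizes: an at least 1.0-fold higher number from compound 2 to compound 4 (0.03 log units; that floor lies within the scatter), and an at least 1.5-fold higher number from compound 3 to compound 4 (0.17 log units; that floor lies within the scatter). Neither floor lies beyond the scatter, so this change is not shown to separate compound 4 from compound 2 or compound 3. Compound 4 is also the second compound in the series to give a limit rather than a number: the limit of > 100000 nM in this assay, at which 2 of the 4 values shown sit.

Going by these compounds, the number behind the limit of compound 4 stays unknown, so its order against compound 2 and compound 3 remains unsettled. Also open, on these data alone, is whether an amine or a carboxylic acid on the phenyl ring, or a longer chain in its place on the carbonyl carbon, would give a clearly lower number.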